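This account rests on a few compounds, and the source may have more. Where it says the series, first, only, none or still open, it means among the compounds named here.

Compound 3 `O=C(NO)c1ccc(/C=C/c2ccnc(-c3ccccc3O)c2)cc1` stands lowest of the three numbers recorded in an assay on isolated protein for inhibition of protein deacetylase HDAC6 (Homo sapiens), read by fluorescence, with a stated time of 15 min; a lower number here means a stronger inhibitor, a higher number a weaker inhibitor: compound 3 gives 47 nM, while compound 2 `O=C(NO)c1cccc(/C=C/c2ccnc(-c3ccccc3O)c2)c1` gives 390 nM and compound 1 `O=C(NO)c1cccc(/C=C/c2ccnc(-c3cc(F)ccc3O)c2)c1` gives 400 nM, both beyond the scatter from compound 3. Compound 4 `O=C(NO)c1ccc(/C=C/c2ccnc(-c3cccc(O)c3)c2)cc1` has not yet been measured in this assay. It differs from compound 3 in one place: 3-hydroxyphenyl in place of 2-hydroxyphenyl on an aromatic carbon.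

Among the measured compounds shown here, only one measured step is available, and it concerns a different position: a 1.0-fold lower number from compound 1 to compound 2 (0.01 log units; within the scatter), a change that lies within the scatter. For the measured compounds named here, no measured pair speaks to moving the hydroxyl from the 2-hydroxyphenyl to the 3-hydroxyphenyl, and no measured pair speaks to a substituent shift on this ring at all. The step from compound 3 to compound 4 therefore cannot be anchored on a directly comparable precedent, and the expectation must rest mainly on compound 3 itself.

Given that, compound 4 is expected to remain in the same region as compound 3, with a modest weakening allowed for: the estimated step is a 2.6-fold higher number from compound 3 to compound 4 (0.41 log units; beyond the scatter). In this assay compound 4 is estimated at 120 nM, within a range from 40 nM to 400 nM.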

Compound 4, half-maximal inhibitory concentration: 19 nM
Compound 4: the middle estimate sits 6.3-fold (0.80 log units) above what was measured; the measured number lies below the stated range.
By their numbers in this assay, from the lowest: compound 4; then compound 3; then compounds 2 and 1 (each within the scatter of the next).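

In this assay, exchanging 2-hydroxyphenyl for 3-hydroxyphenyl on the aromatic carbon next to the ring nitrogen gives a 2.5-fold lower number from compound 3 to compound 4 (0.39 log units; beyond the scatter) and so moves the number in the stronger direction, modestly but measurably. Among the compounds shown here, the two groups carry the same atoms, so this step shows that the number responds to where the hydroxyl sits on this ring alone, which the only earlier step, a 1.0-fold lower number from compound 1 to compound 2 (0.01 log units; within the scatter), could not show, as that exchange of fluoro for hydrogen stayed within the scatter. No accompanying measurement bears on this result, so the data offer no account of why the number moves.

Still open, on these data alone, is whether an amine, a methoxy group or a carboxylic acid in place of the hydroxyl on the 3-hydroxyphenyl group would keep, extend or lose this gain, and whether the hydroxyl itself is needed at all. Also open, as far as these compounds go, is whether the same exchange would give a step of similar size in the core of compound 2, where the number stands at 390 nM with the 2-hydroxyphenyl group in place.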